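The source may hold more compounds than are shown below. What is called first, only, known or untested is meant among the compounds shown, and "the series" means these compounds.

The series contains three measured compounds and one still to be tested. Compound 1 `COc1ccc2[nH]cc(Cc3nn4c(Cc5ccc(OC)c(OC)c5)nnc4s3)c2c1` and compound 2 `COc1ccc(Cc2nnc3sc(Cc4c[nH]c5ccccc45)nn23)cc1OC` share one core, while compound 3 `COc1ccc(Cl)c(-c2nnc3n2NC(c2ccco2)S3)c1` is built on another. For the measured compounds named here, in a functional assay on the whole organism (strain Wistar Albino) for inhibition, with Rattus norvegicus as the target, read by paw edema, with a stated time of 4 h, at a dose of 20 mg/kg (a higher number here means more inhibition at the dose given (going by the name of the read-out), a lower number less inhibition), compound 1 gives 29.6% and compound 2 gives 28.5%; the single measured step, a number 1.1 percentage points lower from compound 1 to compound 2 (within the scatter), is the only comparison available on either core. Compound 3 gives 25.6%, the lowest of the three numbers, though its gaps to compound 2 and to compound 1 both lie within the scatter, so the three compounds cannot be ordered.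

Compound 4 `COc1ccc(Cl)c(-c2nnc3n2NC(c2ccc[nH]2)S3)c1` differs from compound 3 only in the change (1H-pyrrol-2-yl in place of furan-2-yl on a saturated ring carbon). Going by the values given here, no measured step concerns this kind of change or this core; the one step known was of a different sort and within the scatter. Nothing in the data therefore points to a step in this assay beyond the scatter in either direction. The expected step of a number 0.4 percentage points higher from compound 3 to compound 4 (within the scatter) is accordingly taken as negligible. Compound 4 is expected to give about 26%, within a range of 16% to 36%.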

Compound 4, a percentage reported as inhibition, in the whole organism at one dose (the size of the read-out at that dose, not a potency): 20.6%
The estimate for compound 4 lay 5.4 percentage points above the measured number; the measured number falls inside the stated range.
By their numbers in this assay, from the lowest: compounds 4, 3, 2 and 1 (each within the scatter of the next).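

In this assay, for the compounds shown here, the exchange of furan-2-yl for 1H-pyrrol-2-yl on the saturated ring carbon gives a number 5 percentage points lower from compound 3 to compound 4 (within the scatter) and is the first measured step on this core. It shows that replacing a hydrogen-bond acceptor ring with a hydrogen-bond donor ring of the same size does not separate the two compounds beyond the scatter at this position, at this single dose. No measurement of any property of these two rings bears on the result.

The compounds shown leave open whether a quite different group on this ring carbon, such as an amine, a carboxylic acid or a longer alkyl chain, would shift the inhibition beyond the scatter. Going by these compounds, whether compound 3 and compound 4 would separate at another dose or time also remains open.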